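This account rests on a few compounds, and the source may have more. Where it says the series, first, only, none or still open, it means among the compounds named here.

The series shares one core and varies only in the benzyl group bound to the aromatic nitrogen. Compound 1 `CCCSc1nc(N/N=C(\C)c2ccccc2O)c2nnn(Cc3cccc(Cl)c3)c2n1` gives 6500 nM in a functional assay on MGC-803 cells (Homo sapiens) for antiproliferative activity, read by MTT assay, with a stated time of 72 h; a lower number here means a stronger inhibitor, a higher number a weaker inhibitor. Compound 2 `CCCSc1nc(N/N=C(\C)c2ccccc2O)c2nnn(Cc3ccc(F)cc3)c2n1` gives 11000 nM, and compound 3 `CCCSc1nc(N/N=C(\C)c2ccccc2O)c2nnn(Cc3ccc(Cl)cc3)c2n1` gives 7100 nM. Among these three numbers compound 3 stands second highest; its nearest neighbour is shown by a 1.1-fold higher number from compound 1 to compound 3 (0.04 log units; within the scatter) and its furthest by a 1.5-fold lower number from compound 2 to compound 3 (0.19 log units; within the scatter). For the measured compounds named here, every step in the set, including a 1.7-fold higher number from compound 1 to compound 2 (0.23 log units; within the scatter), lies within the scatter, so no compound can be called stronger or weaker than another.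

Compound 4 `CCCSc1nc(N/N=C(\C)c2ccccc2O)c2nnn(Cc3ccc(Br)cc3)c2n1` differs from compound 3 by a single change: bromo in place of chloro on an aromatic carbon. Going by the values given here, the one measured step that bears on this is the halogen exchange on an aromatic carbon, a 1.5-fold lower number from compound 2 to compound 3 (0.19 log units; within the scatter), which stayed within the scatter. Compound 4 is therefore expected to show no step beyond the scatter, a 1.1-fold lower number from compound 3 to compound 4 (0.04 log units; within the scatter). Compound 4 is estimated at 6500 nM, with a range from 3000 nM to 15000 nM.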

Compound 4, half-maximal inhibitory concentration: 11300 nM
Compound 4: the middle estimate sits 1.7-fold (0.24 log units) below what was measured; the measured number falls inside the stated range.
By their numbers in this assay, from the lowest: compounds 1, 3, 2 and 4 (each within the scatter of the next).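

With 4-bromobenzyl, the series now holds three halogens on this aromatic carbon: bromo in place of chloro gives a 1.6-fold higher number from compound 3 to compound 4 (0.20 log units; within the scatter), and bromo in place of fluoro gives a 1.0-fold higher number from compound 2 to compound 4 (0.01 log units; within the scatter). Bromo at this place set against the 3-chlorobenzyl group gives a 1.7-fold higher number from compound 1 to compound 4 (0.24 log units; within the scatter), so compounds 1, 2, 3 and 4 cannot be told apart in this assay, and the exchange of halogens seen earlier between fluoro and chloro now extends to bromo without any step beyond the scatter. Nothing shown here offers a reason for these numbers.

The compounds shown leave open whether a group other than a halogen on this aromatic carbon, such as methoxy, an amine or a carboxylic acid, would give a step beyond the scatter. They also leave open how a longer chain in place of the propyl group on sulfur would read against these four compounds.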